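This account rests on a few compounds, and the source may have more. Where it says the series, first, only, none or still open, it means among the compounds named here.

Measured compounds:
compound 1 `CCN(c1nc(Cl)nc(N[C@H](C)c2ccccc2)n1)C(C)C` with 3550 nM
compound 2 `CCCN(C)c1nc(Cl)nc(N[C@@H](C)c2ccccc2)n1` with 5500 nM

Two compounds have been run in an ADME assay on the whole organism for inhibition, with Oryza sativa as the target, with a stated time of 4 days; a lower number here means a stronger inhibitor, a higher number a weaker inhibitor. Compound 1 gives 3550 nM, and compound 2 gives 5500 nM; compound 1 has the lowest of the two numbers, but its gap to compound 2 lies within the scatter, so the two cannot be ranked against each other on this evidence. Within the data shown here, no step between compounds that differ in one place has been measured, so there is no measured precedent for the change that follows.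

Compound 3 `CC(C)N(c1nc(Cl)nc(N[C@H](C)c2ccccc2)n1)C(C)C` is the next compound to be measured in this assay. It differs from compound 1 by methyl in place of hydrogen on a saturated chain carbon bound to a nitrogen on an aromatic ring and a saturated chain carbon. Among the measured compounds shown here, with no measured step to rest on, the step is expected to be small, with no change beyond the scatter in either direction, and the step of a 1.1-fold lower number from compound 1 to compound 3 (0.05 log units; within the scatter) is what this expectation means. Compound 3 is therefore estimated at 3200 nM, within a range of 1200 nM to 8500 nM.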

Compound 3, half-maximal inhibitory concentration: 1620 nM
Compound 3: middle estimate off by 2.0-fold (0.30 log units), on the high side, within the range that was stated.
By their numbers in this assay, from the lowest: compound 3; then compounds 1 and 2 (each within the scatter of the next).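

Going from ethyl(isopropyl)amino to diisopropylamino gives a 2.2-fold lower number from compound 1 to compound 3 (0.34 log units; beyond the scatter) in this assay, the first step in this set that lies beyond the scatter. It shows that this saturated chain carbon bound to a nitrogen on an aromatic ring is not a silent place: methyl in place of hydrogen there moves the number in the direction of stronger inhibition, though only modestly. This rests on a single pair, and nothing at hand gives a reason for the step.

From the compounds shown here alone, whether a bulkier group at this carbon, such as tert-butyl, or a ring such as cyclopropyl would extend the step or reverse it remains open. So does whether the same methyl would give a comparable step on a different amino group, such as a piperidine or a longer chain.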